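Compound 4: a dichlorophenyl swap on the hydrazone side

The source may hold more compounds than are shown below. What is called first, only, known or untested is meant among the compounds shown, and "the series" means these compounds.

Compound 1 `O=C(Cc1csc2nc(-c3ccc(Br)cc3)cn12)N/N=C/c1ccccc1O` gives 955 nM
Compound 2 `O=C(Cc1csc2nc(-c3ccc(Br)cc3)cn12)N/N=C/c1ccc(O)cc1` gives 17800 nM
Compound 3 `COc1cccc(OC)c1/C=N/NC(=O)Cc1csc2nc(-c3ccc(Br)cc3)cn12` gives 7410 nM

In a functional assay on HCT-15 cells (Homo sapiens) for inhibition, read by sulforhodamine B assay, with a stated time of 48 h (a higher number here means a weaker inhibitor of growth, a lower number a stronger inhibitor of growth), compound 3 holds the middle place of the three (a 7.8-fold higher number from compound 1 to compound 3 (0.89 log units; beyond the scatter)) (a 2.4-fold lower number from compound 2 to compound 3 (0.38 log units; beyond the scatter)). Compound 4 `O=C(Cc1csc2nc(-c3ccc(Br)cc3)cn12)N/N=C/c1ccc(Cl)cc1Cl` differs from it on the carbon with a double bond to nitrogen (2,4-dichlorophenyl in place of 2,6-dimethoxyphenyl on a carbon with a double bond to nitrogen), with 2,4-dichlorophenyl in place of 2,6-dimethoxyphenyl. Changes at this place have moved the number (a 19-fold higher number from compound 1 to compound 2 (1.27 log units; beyond the scatter)), but the larger moves all start from the 2-hydroxyphenyl of compound 1, which neither compound 3 nor compound 4 carries. For the measured compounds named here, no measured compound bears chlorine, so no step beyond the scatter is expected, and no direction can be favoured. The estimated step is small (a 1.3-fold lower number from compound 3 to compound 4 (0.13 log units; within the scatter)). Compound 4 is estimated at 5500 nM, with an expected range from 1300 nM to 22000 nM.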

Compound 4, concentration for 50% growth inhibition: 25700 nM
For compound 4 the middle estimate is 4.7-fold (0.67 log units) below the measured one; measured number outside the range, above it.
By their numbers in this assay, from the lowest: compound 1; then compound 3; then compounds 2 and 4 (each within the scatter of the next).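

In this assay, 2,4-dichlorophenyl is not interchangeable with 2,6-dimethoxyphenyl on the carbon with a double bond to nitrogen: the swap gives (a 3.5-fold higher number from compound 3 to compound 4 (0.54 log units; beyond the scatter)). Against the 4-hydroxyphenyl of compound 2, the new group gives (a 1.4-fold higher number from compound 2 to compound 4 (0.16 log units; within the scatter)), so the two cannot be told apart, even though 2,4-dichlorophenyl has no hydrogen-bond donors or acceptors. The gap to the 2-hydroxyphenyl group (a 27-fold higher number from compound 1 to compound 4 (1.43 log units; beyond the scatter)) leaves compound 1 alone with the lowest number of the four. No evidence here accounts for these steps.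

From the compounds shown here alone, whether an amine in place of the hydroxyl of compound 1 would keep its low number stays open, as does the reading for a phenyl with a single chlorine.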